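The source may hold more compounds than are shown below. What is called first, only, known or untested is meant among the compounds shown, and "the series" means these compounds.

Measured in an ADME assay on the whole organism (strain Han-Wistar) for pharmacokinetics, with Rattus norvegicus as the target, read by LC-MS, at a dose of 2 mg/kg by the oral route; on this read-out higher numbers stand for higher exposure at the dose given and lower numbers for lower exposure:
compound 1 `CN1CCN(CCCS(=O)(=O)c2ccc3nc(NC(=O)NC(=O)c4cccc(-n5cccn5)c4Cl)sc3c2)CC1` gives 12 nM
compound 2 `CN1CCN(CCCS(=O)(=O)c2ccc3nc(NC(=O)NC(=O)c4cc(-n5cccn5)ccc4Cl)sc3c2)CC1` gives 1200 nM
compound 3 `CCc1ccc(Cl)c(C(=O)NC(=O)Nc2nc3ccc(S(=O)(=O)CCCN4CCN(C)CC4)cc3s2)c1` gives 1500 nM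

Compound 3 holds the highest number of the three; its nearest neighbour is compound 2, and the step of a 1.3-fold higher number from compound 2 to compound 3 (0.10 log units; within the scatter) lies within the scatter, so no order between these two is claimed. Compound 1 sits far below both: a 100-fold higher number from compound 1 to compound 2 (2.00 log units; beyond the scatter) and a 130-fold higher number from compound 1 to compound 3 (2.10 log units; beyond the scatter) are large steps, and both concern the group on the carbonyl carbon.

Compound 4 `Cc1cc(C)n(-c2ccc(Cl)c(C(=O)NC(=O)Nc3nc4ccc(S(=O)(=O)CCCN5CCN(C)CC5)cc4s3)c2)n1` differs from compound 3 at one site only: 3,5-dimethyl-1H-pyrazol-1-yl in place of ethyl on an aromatic carbon. Among the measured compounds shown here, the site is the one where compound 3 carries its ethyl, meta to a large group and para to a chloro group. The step that bears directly is a 1.3-fold higher number from compound 2 to compound 3 (0.10 log units; within the scatter), where 1H-pyrazol-1-yl and ethyl at this same site gave numbers within the scatter of each other. The dimethylated pyrazole is not among the measured compounds, so the expectation rests on that single comparison. The change is therefore expected to give only a 1.3-fold lower number from compound 3 to compound 4 (0.10 log units; within the scatter), nothing beyond the scatter. In this assay compound 4 is estimated at 1200 nM, with a range from 400 nM to 3600 nM.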

Compound 4, maximal plasma concentration: 78 nM
Beside the measured number, compound 4's estimate is 15-fold (1.19 log units) above it; the measured number lies below the stated range.
By their numbers in this assay, from the lowest: compound 1; then compound 4; then compounds 2 and 3 (each within the scatter of the next).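

At the site para to a chloro group, the unsubstituted pyrazole and ethyl had given numbers within the scatter of each other, which suggested a site indifferent to the group it carries, but in this assay the series shows a 19-fold lower number from compound 3 to compound 4 (1.28 log units; beyond the scatter) and a 15-fold lower number from compound 2 to compound 4 (1.19 log units; beyond the scatter). The second step is the closer comparison, since 3,5-dimethyl-1H-pyrazol-1-yl and 1H-pyrazol-1-yl differ only in the two methyl groups on the five-membered ring, so exposure at this site depends on substitution of that ring and not merely on whether a pyrazole or an ethyl is present. Nothing measured here explains why exposure falls with this change.

Going by these compounds, whether a pyrazole with a single methyl group would already give a step of this size, and whether the 3-methyl or the 5-methyl position would matter more, remains open. Also open, on these data alone, is how groups of other kinds, such as a propyl chain, an amine or a carboxylic acid, would behave at this site in this assay.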